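Chain-extension on the ether oxygen in the acetophenone series

A few compounds are considered here, and "the series" means these few. Any claim that something is new, unique, unknown or untested is made for them only; others in the source may bear on it.

Compound 2 `C=CCc1cc(C(C)=O)c(O)cc1OCC#N` stands lowest of the two numbers in hand, with 20% in an assay on isolated protein for inhibition of leukotriene B4 receptor 1 (Homo sapiens), tested at 10 uM; a lower number here means less inhibition, a higher number more inhibition at the concentration tested (going by the name of the read-out). Among the measured compounds shown here, the only neighbour, compound 1 `CCc1cc(C(C)=O)c(O)cc1OCCCCCCC#N`, gives 103% in this assay, a value standing well beyond the scatter above compound 2; the two compounds differ in more than one place, so no single step is drawn between them. Compound 3 `C=CCc1cc(C(C)=O)c(O)cc1OCCCCO` has not yet been measured in this assay. Against compound 2 it shows one change: 3-hydroxypropyl in place of cyano on a saturated chain carbon bound to an oxygen on an aromatic ring. For the measured compounds named here, as no step between measured compounds exists, the size is open; the expectation is a rise beyond the scatter, given that compound 1 with 103% carries a longer chain on the same oxygen than compound 2 with 20%. The step from compound 2 to compound 3 is estimated at a number 25 percentage points higher from compound 2 to compound 3 (beyond the scatter). Compound 3 is expected to give 45%, in the range 15% to 80%.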

Compound 3, a percentage reported as inhibition, at one concentration (the size of the read-out at that concentration, not a potency): 48%
The estimate for compound 3 lay 3 percentage points below the measured number; the measured number falls inside the stated range.
By their numbers in this assay, from the lowest: compound 2; then compound 3; then compound 1.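

Replacing cyano with 3-hydroxypropyl on a saturated chain carbon bound to an oxygen on an aromatic ring gives a number 28 percentage points higher from compound 2 to compound 3 (beyond the scatter) in this assay. Among the compounds shown here, this is the first single-place step and shows that the readout responds to a change at this position while the rest of the molecule stays fixed. No measurement bears on the reason for the rise.

The step changes chain length and chain end together, leaving their separate contributions open, and compound 1 differs from both compounds in more than one place, so it cannot settle the matter. A 4-cyanobutyl group, an unsubstituted butyl chain or a butyl chain ending in a carboxylic acid or an amine would test which part of the change carries the effect.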